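Tert-butyl to 4-bromophenyl on a triazole-bearing lactone

The source may hold more compounds than are shown below. What is called first, only, known or untested is meant among the compounds shown, and "the series" means these compounds.

Compound 1 `CC(C)(C)c1cn(C[C@H](O)[C@H]2OC(=O)C(OCc3ccccc3)=C2OCc2ccccc2)nn1` is one of three close analogues tested in a functional assay on A549 cells (Homo sapiens) for antiproliferative activity, read by MTT assay, with a stated time of 72 h; on this read-out lower numbers stand for stronger inhibition and higher numbers for weaker inhibition. In this assay compound 1 gives 34000 nM, the higher of the two numbers that were obtained; its nearest neighbour is compound 2 `O=C1O/C(=C\Cn2cc(-c3cccc(O)c3)nn2)C(OCc2ccccc2)=C1OCc1ccccc1`, which gives 23300 nM, a gap within the scatter. Compound 3 `COc1ccccc1-c1cn(C/C=C2\OC(=O)C(OCc3ccccc3)=C2OCc2ccccc2)nn1` reached only a limit of this assay, > 100000 nM, and so (the limit of > 100000 nM in this assay, at which 1 of the 3 values shown sits). Among the measured compounds shown here, the one measured step, an at least 4.2-fold higher number from compound 2 to compound 3 (0.63 log units; beyond the scatter), is the only comparison available.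

Compound 4 `O=C1O[C@H]([C@@H](O)Cn2cc(-c3ccc(Br)cc3)nn2)C(OCc2ccccc2)=C1OCc1ccccc1` differs from compound 1 in one place: 4-bromophenyl in place of tert-butyl on an aromatic carbon. For the measured compounds named here, no measured step swaps an alkyl for an aryl group on that ring, and the step from compound 2 to compound 3 concerns two aryl groups on a different core, so it bears on compound 4 only loosely, showing that the identity of an aryl group can shift the number by at least a modest amount. Compound 2, carrying an aryl group, sits within the scatter of compound 1, and on that basis the estimate for compound 4 is a 1.1-fold lower number from compound 1 to compound 4 (0.05 log units; within the scatter), a change not expected to exceed the scatter. Compound 4 is therefore expected to give about 30000 nM, within 8000 nM to 120000 nM.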

Compound 4, half-maximal inhibitory concentration: 750 nM
Compound 4: middle estimate off by 40-fold (1.60 log units), on the high side; measured number outside the range, below it.
By their numbers in this assay, from the lowest: compound 4; then compounds 2 and 1 (each within the scatter of the next). At a limit, above all of these: compound 3.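

In this assay, putting 4-bromophenyl in place of tert-butyl on this aromatic carbon gives a 45-fold lower number from compound 1 to compound 4 (1.66 log units; beyond the scatter), so the group held at this place on the five-membered aromatic ring can move the number by a large amount with the rest of the molecule unchanged. Among the compounds shown here, the only earlier step compared two aryl groups on a different core, whereas this step exchanges an open alkyl group for an aryl group on the core of compound 1, and it shows that this exchange reaches far beyond the scatter. Nothing measured here gives a reason for the change.

A plain phenyl, a 4-chlorophenyl or a 4-methoxyphenyl on the same carbon would show whether the six-membered aromatic ring or the bromine that enters with it accounts for the step. From the compounds shown here alone, it also remains open whether the same exchange carries over to the core of compound 2, and what an amine or a longer alkyl chain would do at this place.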